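Swapping the ether substituent across two sulfonamide cores

The source may hold more compounds than are shown below. What is called first, only, known or untested is meant among the compounds shown, and "the series" means these compounds.

Compound 1 `CC(C)(NS(=O)(=O)c1cccc(OCC2CC2)c1)c1ccc(Cn2ccc(=O)[nH]c2=O)cc1` and compound 2 `CC(C)(NS(=O)(=O)c1cccc(OC2CCCC2)c1)c1ccc(Cn2ccc(=O)[nH]c2=O)cc1` share one core, and in an assay on HeLa cells for inhibition of Deoxyuridine 5'-triphosphate nucleotidohydrolase, mitochondrial (Homo sapiens), read by crystal violet staining, with a stated time of 24 h (on this read-out lower numbers stand for an effect already at smaller amounts and higher numbers for an effect only at larger amounts of compound), compound 1 gives 140 nM while compound 2 gives 120 nM. Among the measured compounds shown here, the single change between them is cyclopentyl in place of cyclopropylmethyl on an oxygen on an aromatic ring, and it produced a 1.2-fold lower number from compound 1 to compound 2 (0.07 log units; within the scatter), so the two numbers are read as the same within the scatter of the method.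

Compound 3 `C[C@@H](NS(=O)(=O)c1ccc(Cn2ccc(=O)[nH]c2=O)cc1)c1cccc(OCC2CC2)c1` is built on a different core; the difference between the two cores is not broken down here. In this assay compound 3 gives 930 nM, the highest of the three numbers, with compound 1 lying closest and compound 2 furthest, and both of those gaps are beyond the scatter.

Compound 4 `C[C@@H](NS(=O)(=O)c1ccc(Cn2ccc(=O)[nH]c2=O)cc1)c1cccc(OC2CCCC2)c1` has not been measured. It stands to compound 3 as compound 2 stands to compound 1: the change is cyclopentyl in place of cyclopropylmethyl on an oxygen on an aromatic ring, the same change at the same place, on an oxygen on an aromatic ring whose other neighbours are aromatic carbon, and it is the only repeated change among the compounds shown. Because the measured instance a 1.2-fold lower number from compound 1 to compound 2 (0.07 log units; within the scatter) stayed within the scatter, the expected step is a 1.2-fold lower number from compound 3 to compound 4 (0.07 log units; within the scatter). This expectation rests on one pair on a different core, so the range is kept broad. Compound 4 is estimated at 800 nM, between 400 nM and 1700 nM.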

Compound 4, half-maximal effective concentration: 610 nM
For compound 4 the middle estimate is 1.3-fold (0.12 log units) above the measured one; the range from low to high includes it.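

In this assay, replacing cyclopropylmethyl with cyclopentyl on the core of compound 3 gives a 1.5-fold lower number from compound 3 to compound 4 (0.18 log units; within the scatter), so on this core too the two ether groups cannot be told apart. Set side by side, the two steps do not differ, and the change reads the same on both cores: the same change on two cores in this assay, a 1.2-fold lower number (0.07 log units; within the scatter) from compound 1 to compound 2 and a 1.5-fold lower number (0.18 log units; within the scatter) from compound 3 to compound 4, 1.3-fold (0.12 log units) apart, within the scatter of two such steps. This shows that this one change, on an oxygen on an aromatic ring, carried over between these two cores without a step beyond the scatter, but neither step is large enough to test whether a change with a clear effect would carry over in the same way, and two pairs in a single assay make no rule for other cores.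

The compounds shown carry only cyclopropylmethyl and cyclopentyl on that oxygen, so it remains open what a group of another kind there, such as an amine, a carboxylic acid or a longer chain, would do on either core. Also open is which part of the difference between the two cores matters for this read-out, as the compounds shown do not break that difference down into single changes.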